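From isopropyl to 4-fluorophenyl on a shared core

The source may report more compounds than this note shows. Statements on the series, on what has been measured and on what is new or still open speak of the compounds shown alone.

In a functional assay on HeLa cells (Homo sapiens) for antiproliferative activity, read by MTT assay, with a stated time of 72 h (on this read-out lower numbers stand for stronger inhibition and higher numbers for weaker inhibition), compound 1 `COc1cc(-c2nccn2C(C)C)cc(OC)c1OC` reads > 100000 nM, which is a limit and not a number. Compound 1 thus stands at the limit of > 100000 nM in this assay, at which 2 of the 3 values shown sit. Compound 2 `COc1cc(-c2nccn2S(=O)(=O)c2ccccc2)cc(OC)c1OC` reads > 100000 nM, also a limit. Only compound 3 `COc1cc(-c2nccn2-c2ccc3cc[nH]c3c2)cc(OC)c1OC` gives a number, 4800 nM. Compound 4 `COc1cc(-c2nccn2-c2ccc(F)cc2)cc(OC)c1OC` carries 4-fluorophenyl in place of isopropyl on an aromatic nitrogen. Within the data shown here, no measured step isolates this change, so the expectation rests on compound 3 at 4800 nM, which also lacks the isopropyl on that nitrogen. Stronger inhibition in this assay is expected, by more than the scatter. The estimated step is an at least 5.0-fold lower number from compound 1 to compound 4 (0.69 log units; beyond the scatter). For compound 4 the expected value is 20000 nM, with an estimated range from 4000 nM to 90000 nM.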

Compound 4, half-maximal inhibitory concentration: 17500 nM
For compound 4 the middle estimate is 1.1-fold (0.06 log units) above the measured one, and the stated range covers the measured number.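

Among these compounds, replacing isopropyl with 4-fluorophenyl on the aromatic nitrogen gives in this assay the only step that can be read at this position: an at least 5.7-fold lower number from compound 1 to compound 4 (0.75 log units; beyond the scatter). A number therefore appears at this nitrogen with the six-membered aromatic ring of carbon only where isopropyl gave none. The size of the step has only a floor, since compound 1 reads as a limit and not a number: the limit of > 100000 nM in this assay, at which 2 of the 4 values shown sit. The compounds shown leave open what the fluorine contributes beyond the ring itself, and how a plain phenyl or an aminophenyl on this nitrogen would read.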